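The source may report more compounds than this note shows. Statements on the series, on what has been measured and on what is new or still open speak of the compounds shown alone.

Compound 3 `CC(C)COc1cc(C(F)(F)F)ccc1CNC(=O)C(C)c1ccc(NS(C)(=O)=O)c(F)c1` gives the lowest number of the three compounds measured in an assay on CHO cells for antagonist activity at transient receptor potential cation channel subfamily V member 1 (Homo sapiens), read by FLIPR (on this read-out lower numbers stand for stronger inhibition and higher numbers for weaker inhibition), at 0.8 nM. Compound 1 `CC(C(=O)NCc1ccc(C(F)(F)F)cc1N1CCCCCC1)c1ccc(NS(C)(=O)=O)c(F)c1` gives 1.6 nM, and compound 2 `CC(C(=O)NCc1ccc(C(F)(F)F)cc1N1CCCCCCC1)c1ccc(NS(C)(=O)=O)c(F)c1` gives 2.8 nM; the steps of a 2.0-fold lower number from compound 1 to compound 3 (0.30 log units; within the scatter) and a 3.5-fold lower number from compound 2 to compound 3 (0.54 log units; beyond the scatter) show how compound 3 stands against them. Compound 4 `CC(C)CCOc1cc(C(F)(F)F)ccc1CNC(=O)C(C)c1ccc(NS(C)(=O)=O)c(F)c1` differs from compound 3 by isobutyl in place of isopropyl on a saturated chain carbon bound to an oxygen on an aromatic ring. Within the data shown here, no measured step changes this chain; the only step that adds one carbon to a group on the core, a 1.8-fold higher number from compound 1 to compound 2 (0.24 log units; within the scatter), stays within the scatter. Compound 4 is therefore expected to show no change beyond the scatter, a step of a 1.3-fold higher number from compound 3 to compound 4 (0.10 log units; within the scatter), and its estimated value in this assay is 1 nM, with a range from 0.4 nM to 2.5 nM.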

Compound 4, inhibition constant: 0.5 nM
Compound 4: middle estimate off by 2.0-fold (0.30 log units), on the high side; the measured number falls inside the stated range.
By their numbers in this assay, from the lowest: compounds 4, 3, 1 and 2 (each within the scatter of the next, the first and the last beyond it).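

Going from isobutoxy to isopentyloxy leaves the number in this assay within the scatter, a 1.6-fold lower number from compound 3 to compound 4 (0.20 log units; within the scatter), so this chain accepts one more carbon without a step beyond it. Compound 4 also stands beyond the scatter against both cyclic amines, a 3.2-fold lower number from compound 1 to compound 4 (0.51 log units; beyond the scatter) and a 5.6-fold lower number from compound 2 to compound 4 (0.75 log units; beyond the scatter), whereas compound 3 did so only against compound 2. Nothing given here explains these steps. As far as these compounds go, it remains open whether a longer chain, such as hexyloxy, or a chain ending in an amine or a carboxylic acid would hold these low numbers.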